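A few compounds are considered here, and "the series" means these few. Any claim that something is new, unique, unknown or untested is made for them only; others in the source may bear on it.

Measured so far in a functional assay on HepG2 cells (Homo sapiens) for cytotoxicity, read by MTT assay, with a stated time of 48 h; a higher number here means a weaker inhibitor, a lower number a stronger inhibitor: compound 1 `COc1ccc(CNC(=O)CSc2nc3ccc(NC(C)=O)cc3s2)cc1` gives 11200 nM, and compound 2 `O=C(CSc1nc2ccc(NC(=O)c3ccccc3)cc2s1)NCc1ccccc1` gives 34200 nM.

Of these two numbers, compound 2 holds the higher one, and its gap to compound 1 lies beyond the usual scatter. Compound 3 `COc1ccc(CNC(=O)CSc2nc3ccc(NC(=O)c4ccccc4)cc3s2)cc1` differs from compound 2 by methoxy in place of hydrogen on an aromatic carbon. Among the compounds with values here, no single-change step among the measured compounds covers this change, so the expectation rests on little; compound 1, which carries the methoxy group, shows the lower number in this assay. The step expected a 1.4-fold lower number from compound 2 to compound 3 (0.15 log units; within the scatter) is a modest lowering, possibly within the scatter. Compound 3 is estimated at 24000 nM, with a range from 9000 nM to 60000 nM.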

Compound 3, half-maximal inhibitory concentration: 12700 nM
The estimate for compound 3 lay 1.9-fold (0.28 log units) above the measured number; measured number inside the range.
By their numbers in this assay, from the lowest: compounds 1 and 3 (each within the scatter of the next); then compound 2.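

In this assay methoxy in place of hydrogen on an aromatic carbon, para to a large group, gives a 2.7-fold lower number from compound 2 to compound 3 (0.43 log units; beyond the scatter) and thus shows the benzyl to 4-methoxybenzyl change acting alone, which compounds 1 and 2 could not show. With the 4-methoxybenzyl group in place, phenyl in place of methyl on the carbonyl carbon gives a 1.1-fold higher number from compound 1 to compound 3 (0.05 log units; within the scatter) and leaves those two compounds level. Nothing given here accounts for either step. Going by these compounds, whether a hydroxyl group or an amine on that same aromatic carbon would act as methoxy does remains open, as does the effect of a longer chain there.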